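Nitrile chain length on the acetylphenol series

The source may hold more compounds than are shown below. What is called first, only, known or untested is meant among the compounds shown, and "the series" means these compounds.

Measured so far in an assay on isolated protein for binding affinity to leukotriene B4 receptor 1 (Homo sapiens), tested at 1 uM; on this read-out lower numbers stand for less inhibition and higher numbers for more inhibition at the one concentration tested (going by the name of the read-out):
compound 1 `CCc1cc(C(C)=O)c(O)cc1OCCCCC#N`: 57%
compound 2 `CC(=O)c1cc(C=O)c(OCCCCC#N)cc1O`: 3%
compound 3 `C=CCc1cc(C(C)=O)c(O)cc1OCCCC#N`: 6%

Compound 3 stands second highest of the three, within the scatter of compound 2 and well apart from compound 1. Compound 4 `C=CCc1cc(C(C)=O)c(O)cc1OCCCCC#N` differs from compound 3 by cyanomethyl in place of cyano on a saturated chain carbon, three bonds along the chain from an oxygen on an aromatic ring. Among the compounds with values here, the one measured step, a number 54 percentage points lower from compound 1 to compound 2 (beyond the scatter), concerns a different position and does not bear on this chain change. Within the data shown here, compound 1 carries the same chain as compound 4 yet differs from compound 3 in a second place as well, so no single step tracks the extension. Compound 4 is expected to gain, roughly a number 24 percentage points higher from compound 3 to compound 4 (beyond the scatter), with wide uncertainty. Compound 4 is estimated at 30%, between 5% and 60%.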

Compound 4, a percentage reported as inhibition, at one concentration (the size of the read-out at that concentration, not a potency): 57%
For compound 4 the middle estimate is 27 percentage points below the measured one; low and high end bracket the measured number.
By their numbers in this assay, from the lowest: compounds 2 and 3 (each within the scatter of the next); then compounds 1 and 4 (each within the scatter of the next).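

In this assay, cyanomethyl in place of cyano on a saturated chain carbon, three bonds along the chain from an oxygen on an aromatic ring, gives a number 51 percentage points higher from compound 3 to compound 4 (beyond the scatter) with the allyl group held constant, so the 3-cyanopropyl to 4-cyanobutyl change alone carries a large step. With the 4-cyanobutyl chain held, allyl in place of formyl gives a number 54 percentage points higher from compound 2 to compound 4 (beyond the scatter) and vinyl in place of methyl gives no change at the digits printed from compound 1 to compound 4 (within the scatter) on the saturated chain carbon bound to an aromatic carbon. Nothing available explains why this chain change matters so much.

Still open, from the compounds shown here alone, is whether a longer chain, or a carboxylic acid in place of the nitrile, keeps this level of inhibition.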